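Swapping the cyanoguanidine for a thiourea at the chain end

This account rests on a few compounds, and the source may have more. Where it says the series, first, only, none or still open, it means among the compounds named here.

Measured in a functional assay on the whole organism (stomach) with Rattus norvegicus as the target; a higher number here means that more compound is needed for the effect, a lower number that less compound is needed:
Compound 1 `CCC/N=C(/NC#N)NCCCCn1nc(-c2ccccc2)ccc1=O` — > 100 mg/kg, a limit of the assay, not a number.
Compound 2 `C/N=C(/NC#N)NCCCCn1nc(-c2ccc(Cl)cc2)ccc1=O` — 100 mg/kg.
Compound 3 `NC(=O)SCCCCCN1NC=CC=C1c1ccccc1` — 23.8 mg/kg.

Compound 1 stands at the limit (the limit of > 100 mg/kg in this assay, at which 1 of the 3 values shown sits), so only a bound is known for it. Compound 4 `CC(C)(C)/N=C(\S)NCCCCn1nc(-c2ccccc2)ccc1=O` keeps the shared core of compound 1 and changes the chain end: a group of 7 heavy atoms (5 carbon, 1 nitrogen, 1 sulfur; no ring) in place of a group of 8 heavy atoms (5 carbon, 3 nitrogen; no ring), on an amine nitrogen. For the measured compounds named here, no pair of measured compounds differing in one place is available here, so no measured step guides this change. With compound 1 known only as a limit, the expected step from compound 1 to compound 4 is taken as a modest improvement, an at least 2.0-fold lower number from compound 1 to compound 4 (0.30 log units; that floor lies within the scatter). For compound 4, the expected dose in this assay is 50 mg/kg, within a range from 15 mg/kg to 200 mg/kg.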

Compound 4, dose for half-maximal effect: > 100 mg/kg
Compound 4: no number, only a limit (the forecaster's own chance of this, stated with the estimate: 40%); middle value at least 2.0-fold (0.30 log units) away from the limit.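

Compound 1 and compound 4 both sit at a limit of this assay rather than at a number, so no step can be read between them: the limit of > 100 mg/kg in this assay, at which 2 of the 4 values shown sit.

Going by these compounds, whether this change at the chain end alters the dose needed remains open.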